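The compounds below may be only part of what the source reports. "The series", "measured", "known", "first", "only" and "open" are said of these compounds alone.

Working notes on the series. Compound 1 `Cc1ccnc(Nc2cc(N3CCNCC3)nc3ccnn23)c1` in an assay on isolated protein for inhibition of Dipeptidyl peptidase 9 (Homo sapiens) (a lower number here means a stronger inhibitor, a higher number a weaker inhibitor), gives > 100000 nM, which is a limit of the assay and not a number. Compound 2 `N[C@@H]1CCCN(c2cc(Nc3cc(Cl)ccn3)n3nccc3n2)C1` gives > 50000 nM in this assay, again a limit rather than a number. Among the compounds with values here, compound 2 therefore stands at the limit of > 50000 nM in this assay, at which 1 of the 2 values shown sits, and no measured step between compounds exists in this set. Compound 3 `N[C@@H]1CCCN(c2cc(Nc3ccccc3Cl)n3nccc3n2)C1` is not yet measured; it differs from compound 2 by 2-chlorophenyl in place of 4-chloropyridin-2-yl on a nitrogen on an aromatic ring. Within the data shown here, with no measured step to rest on, the expected step that the limit leaves unreadable from compound 2 to compound 3 is none beyond the scatter. Compound 3 is estimated at 60000 nM, within 10000 nM to 200000 nM, and is expected most likely to return only a limit again.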

Compound 3, half-maximal inhibitory concentration: > 100000 nM
Compound 3: only a limit was reported; the forecaster's own chance of this, stated with the estimate: 70%; middle value at least 1.6-fold (0.22 log units) away from the limit.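

Within the data shown here, compound 2 and compound 3 both return only limits in this assay, so no step between them can be read. The compounds shown leave open whether any change on the shared core gives a measurable value in this assay.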